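Replacing a hydroxyphenyl with a dichlorophenyl on a pyrazolone imine

The compounds below may be only part of what the source reports. "The series", "measured", "known", "first", "only" and "open" are said of these compounds alone.

Compound 1 `CCOc1cccc(/C=N/c2c(C)n(C)n(-c3ccccc3)c2=O)c1`: 724000000 nM
Compound 2 `Cc1c(/N=C/c2cccc(O)c2)c(=O)n(-c2ccccc2)n1C`: 372000000 nM
Compound 3 `Cc1c(/N=C/c2cccc([N+](=O)[O-])c2)c(=O)n(-c2ccccc2)n1C`: 490000000 nM

All three were tested in a functional assay on DLD-1 cells (Homo sapiens) for cytotoxicity, read by MTT assay, with a stated time of 72 h; on this read-out lower numbers stand for stronger inhibition and higher numbers for weaker inhibition. Compound 2 gives the smallest of the three numbers, but its gaps to the others stay within the scatter: a 1.9-fold lower number from compound 1 to compound 2 (0.29 log units; within the scatter) and a 1.3-fold higher number from compound 2 to compound 3 (0.12 log units; within the scatter). Compound 4 `Cc1c(/N=C/c2ccc(Cl)cc2Cl)c(=O)n(-c2ccccc2)n1C` is not yet measured; it differs from compound 2 by 2,4-dichlorophenyl in place of 3-hydroxyphenyl on a carbon with a double bond to nitrogen. The steps seen so far, which all swap one small group on that same aromatic ring, were each within the scatter, including a 1.5-fold lower number from compound 1 to compound 3 (0.17 log units; within the scatter). On that basis no step beyond the scatter is expected in this assay for compound 4, and the estimate is 450000000 nM (range 150000000 nM to 1300000000 nM), meaning an expected step of a 1.2-fold higher number from compound 2 to compound 4 (0.08 log units; within the scatter).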

Compound 4, half-maximal inhibitory concentration: 126000000 nM
Compound 4: the middle estimate sits 3.6-fold (0.55 log units) above what was measured; the measured number lies below the stated range.
By their numbers in this assay, from the lowest: compound 4; then compounds 2, 3 and 1 (each within the scatter of the next).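

In this assay, for the compounds shown here, the exchange of the whole substituted ring gives a 3.0-fold lower number from compound 2 to compound 4 (0.47 log units; beyond the scatter) and is the only step here beyond the scatter, while the smaller swaps on that ring all stayed within it. The number at this carbon with a double bond to nitrogen can therefore shift when 2,4-dichlorophenyl enters in place of 3-hydroxyphenyl. Nothing measured here explains this shift.

The step cannot be divided between losing the hydroxy group and gaining the two chlorines. As far as these compounds go, how a ring carrying one chlorine, an amine or a carboxylic acid would compare remains open.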